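The compounds below may be only part of what the source reports. "The series", "measured", "known", "first", "only" and "open" are said of these compounds alone.

Compound 3 `COc1cccc(OC)c1OCCNCCOc1ccccc1OCc1ccc(Cl)cc1` stands second highest of the three numbers in a functional assay on spleen for antagonist activity at Alpha-1B adrenergic receptor (Rattus norvegicus) (a lower number here means a less potent compound, a higher number a more potent compound, by a factor of ten per unit of this negative logarithm), where compound 3 gives 8.06. Compound 1 `COc1cccc(OC)c1OCCNCCOc1ccccc1OCc1ccccc1` gives 8.3 in this assay, and compound 2 `COc1cccc(OC)c1OCCNCCOc1ccccc1OCc1ccccc1Cl` gives 7.52. Compound 4 `COc1cccc(OC)c1OCCNCCOc1ccccc1OCc1ccc(C)cc1` has not yet been measured; it differs from compound 3 by methyl in place of chloro on an aromatic carbon. Among the compounds with values here, two measured steps bear on this change. a number 0.24 log units lower from compound 1 to compound 3 (within the scatter), so chloro at this place leaves the number within the scatter, while a number 0.54 log units higher from compound 2 to compound 3 (beyond the scatter). Within the data shown here, no measured step exchanges chloro for methyl, so the swap is expected to stay within the scatter in this assay. Compound 4 is therefore estimated at 8.1 with a range of 7.6 to 8.6, which amounts to an expected step of a number 0.04 log units higher from compound 3 to compound 4 (within the scatter).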

Compound 4, negative logarithm of the antagonist equilibrium constant: 8.43
Compound 4: the middle estimate sits 0.33 log units below what was measured; measured number inside the range.
By their numbers in this assay, from the lowest: compound 2; then compounds 3, 1 and 4 (each within the scatter of the next, the first and the last beyond it).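

In this assay the change of chloro to methyl on this aromatic carbon gives a number 0.37 log units higher from compound 3 to compound 4 (beyond the scatter) and so moves the number beyond the scatter, whereas methyl in place of hydrogen gives a number 0.13 log units higher from compound 1 to compound 4 (within the scatter) and stays within it. The step of a number 0.91 log units higher from compound 2 to compound 4 (beyond the scatter) for 4-methylphenyl in place of 2-chlorophenyl is the widest among these compounds. Nothing measured here explains these steps. Open, on these data alone, is how methoxy or ethyl at this place would compare with methyl, and how methyl would read in place of the chloro of compound 2.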